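From Compound 2 to Compound 4: One Aryl Group Swapped

The compounds below may be only part of what the source reports. "The series", "measured", "known", "first", "only" and "open" are said of these compounds alone.

In a functional assay on MOLT-4 cells (Homo sapiens) for antiproliferative activity, read by MTT assay, with a stated time of 48 h (on this read-out higher numbers stand for weaker inhibition and lower numbers for stronger inhibition), compound 2 `O=C(CCCCCn1cc(Nc2ncc(Cl)c(Nc3cccc(Cl)c3)n2)cn1)NO` gives 80 nM. Compound 3 `CNc1nc(Nc2cnn(CCCCCCC(=O)NO)c2)ncc1Cl` gives 110 nM, which lies within the scatter of the value for compound 2. Compound 1 `COc1ccc(Nc2nc(Nc3cnn(CCCCCCC(=O)NO)c3)ncc2Cl)cc1` gives 170 nM, and its gap to compound 2 lies beyond the scatter.

Compound 4 `O=C(CCCCCn1cc(Nc2ncc(Cl)c(Nc3ccc(F)cc3)n2)cn1)NO` carries 4-fluorophenyl in place of 3-chlorophenyl on a nitrogen on an aromatic ring. Within the data shown here, no measurement yet shows this exact exchange. The closest evidence is a different exchange on such a nitrogen, a 1.5-fold lower number from compound 1 to compound 3 (0.19 log units; within the scatter), where methyl replaces 4-methoxyphenyl. Even that larger change in the group stays within the scatter, although it was measured on a different chain from the one in compound 2.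

A shift beyond the scatter in this assay is therefore not expected, and no direction can be favoured. The estimated change is a 1.1-fold higher number from compound 2 to compound 4 (0.05 log units; within the scatter). For compound 4 the expected value is 90 nM, with an estimated range from 40 nM to 200 nM.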

Compound 4, half-maximal inhibitory concentration: 120 nM
The estimate for compound 4 lay 1.3-fold (0.12 log units) below the measured number; the range from low to high includes it.
By their numbers in this assay, from the lowest: compounds 2, 3, 4 and 1 (each within the scatter of the next, the first and the last beyond it).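

In this assay, the exchange of 3-chlorophenyl for 4-fluorophenyl on a nitrogen on an aromatic ring gives a 1.5-fold higher number from compound 2 to compound 4 (0.18 log units; within the scatter), so this assay does not separate these two groups. This is the first step shown on the chain of compound 2, and the first in which one substituted phenyl group replaces another at this position; the earlier step at this position replaced 4-methoxyphenyl with methyl on a different chain. Nothing available bears on what lies behind this result.

As far as these compounds go, it remains open whether a group carrying an amine or a carboxylic acid at this position would also stay within the scatter. The effect of the chain alone also remains open, since no pair shown differs only there, and a longer chain is not among these compounds.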